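The source may report more compounds than this note shows. Statements on the series, on what has been measured and on what is new or still open speak of the compounds shown alone.

Measured in a functional assay on K562 cells (Homo sapiens) for cytotoxicity, read by trypan blue exclusion, with a stated time of 96 h; on this read-out lower numbers stand for stronger inhibition and higher numbers for weaker inhibition:
Compound 1 `COC(=O)[C@H](C)Nc1cc(CS(=O)(=O)/C=C/c2c(OC)cc(OC)cc2OC)ccc1OC`: 200 nM
Compound 2 `COC(=O)C(Nc1cc(CS(=O)(=O)/C=C/c2c(OC)cc(OC)cc2OC)ccc1OC)c1ccccc1`: 30 nM

Among the measured compounds shown here, of these two, compound 2 holds the lower number, and compound 1 is its only neighbour. Compound 3 `COC(=O)C(Nc1cc(CS(=O)(=O)/C=C/c2c(OC)cc(OC)cc2OC)ccc1OC)c1ccc(Cl)cc1` keeps everything in compound 2 except one spot, where the phenyl becomes 4-chlorophenyl: chloro in place of hydrogen on an aromatic carbon. For the measured compounds named here, only one measured step bears on this, and only loosely: a 6.7-fold lower number from compound 1 to compound 2 (0.82 log units; beyond the scatter), a modest change that brought in the phenyl ring now being substituted. Going by the values given here, no measured compound carries a substituent on that ring, so the data give no direction for the new change. A shift within the scatter is therefore expected in this assay. The expected change is a 1.2-fold higher number from compound 2 to compound 3 (0.07 log units; within the scatter). Compound 3 is estimated at 35 nM, with an expected range from 12 nM to 100 nM.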

Compound 3, half-maximal inhibitory concentration: 200 nM
The estimate for compound 3 lay 5.7-fold (0.76 log units) below the measured number; the measured number lies above the stated range.
By their numbers in this assay, from the lowest: compound 2; then compounds 1 and 3 (each within the scatter of the next).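

In this assay, the place on the phenyl ring of compound 2 para to a large group proves sensitive to substitution: chloro in place of hydrogen gives a 6.7-fold higher number from compound 2 to compound 3 (0.82 log units; beyond the scatter) and thus reverses a gain of the same size, seen as a 6.7-fold lower number from compound 1 to compound 2 (0.82 log units; beyond the scatter) when the phenyl-bearing group replaced 1-(methoxycarbonyl)ethyl. Compound 3 therefore sits level with compound 1, with no change at the digits printed from compound 1 to compound 3 (within the scatter) on replacing 1-(methoxycarbonyl)ethyl by (4-chlorophenyl)(methoxycarbonyl)methyl, so a single chlorine atom is enough to remove the advantage of compound 2. Nothing available accounts for this shift.

Whether the loss is particular to chloro remains open, since the compounds shown do not tell how a fluoro, a methoxy or an amine would behave in that place. They also leave open how chloro would behave elsewhere on that ring.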